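Swapping Methoxy for Fluoro on the Core of Compound 3

This account rests on a few compounds, and the source may have more. Where it says the series, first, only, none or still open, it means among the compounds named here.

Compound 3 `COc1ccc2ncc(S(=O)(=O)c3cccc(Cl)c3)c(N3CCC(C)CC3)c2c1` sits at the bottom of the three numbers in an assay on isolated protein for displacement of a labelled ligand from metabotropic glutamate receptor 5 (Homo sapiens), with a stated time of 60 min, tested at 1 uM (a lower number here means less inhibition, a higher number more inhibition at the concentration tested (going by the name of the read-out)), where compound 3 gives -3%. Within the data shown here, its nearest neighbour, compound 1 `COc1ccc(S(=O)(=O)c2cnc3ccc(OC)cc3c2N2CCC(C)CC2)cc1`, gives 41%; the one measured step reaching compound 3 is a number 44 percentage points lower from compound 1 to compound 3 (beyond the scatter), a change on the sulfonyl sulfur rather than on the core. Compound 2 `Cc1ccc(S(=O)(=O)c2cnc3ccc(F)cc3c2N2CCC(C)CC2)cc1C` gives 92% but differs from compound 3 in two places, so its number cannot be tied to a single change. Compound 4 `CC1CCN(c2c(S(=O)(=O)c3cccc(Cl)c3)cnc3ccc(F)cc23)CC1` differs from compound 3 by fluoro in place of methoxy on an aromatic carbon. Among the measured compounds shown here, no measured step tests this swap alone, so the direction is uncertain. A modest rise is expected, a number 23 percentage points higher from compound 3 to compound 4 (beyond the scatter), partly because fluoro-bearing compound 2 gives 92%. Compound 4 is therefore estimated at 20%, within -10% to 55%.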

Compound 4, a percentage reported as inhibition, at one concentration (the size of the read-out at that concentration, not a potency): 92%
For compound 4 the middle estimate is 72 percentage points below the measured one, outside the stated range (above it).
By their numbers in this assay, from the lowest: compound 3; then compound 1; then compounds 2 and 4 (each within the scatter of the next).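

In this assay, fluoro in place of methoxy on this aromatic carbon gives a number 95 percentage points higher from compound 3 to compound 4 (beyond the scatter), so this single swap on the core, with the 3-chlorophenyl group held fixed, can carry a large step. With fluoro on the core, 3-chlorophenyl in place of 3,4-dimethylphenyl gives no change at the digits printed from compound 2 to compound 4 (within the scatter), so these two groups on the sulfonyl sulfur cannot be told apart here. No evidence is available to explain the large step. Still open, on these data alone, is how an amine, a nitrile or chloro at this position would compare with fluoro and methoxy. Also open, as far as these compounds go, is whether fluoro gives a similar rise alongside the 4-methoxyphenyl group.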